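The source may report more compounds than this note shows. Statements on the series, on what has been measured and on what is new or still open speak of the compounds shown alone.

The measured compounds, all tested in a functional assay on the whole organism (strain Hartley) for inhibition, with Cavia porcellus as the target, with stated times of 15 min and 2 min; a lower number here means that less compound is needed, a higher number that more compound is needed for the effect:

Compound 1, `CCCCC1([C@H](O)/C=C/C2CCC(=O)[C@@H]2CCCCCCCCC(=O)OCC)CCC1` — compound 1 gives 6.21 mg/kg.
Compound 2, `CCCCC1([C@H](O)/C=C/C2CCC(=O)[C@@H]2C/C=C\CCCC(=O)O)CCC1` — compound 2 gives 0.0022 mg/kg.
Compound 3, `CCCCC1([C@H](O)/C=C/C2CCC(=O)[C@@H]2C/C=C\CCCC(=O)OCC)CCC1` — compound 3 gives 0.221 mg/kg.

Compound 1 stands highest of the three numbers in this assay. Its nearest neighbour is compound 3, with a number well below it, beyond the scatter; compound 2 lies furthest away, far below. Within the data shown here, the only step between two compounds that differ in one place is a 100-fold higher number from compound 2 to compound 3 (2.00 log units; beyond the scatter), which concerns the oxygen next to the carbonyl group. Compound 1 and compound 3 differ in the chain; their two values show compound 1 with the higher number, and nothing more can be drawn from that pair.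

Compound 4 is `CCCCC1([C@H](O)/C=C/C2CCC(=O)[C@@H]2CCCCSCC(=O)OCC)CCC1`. It differs from compound 1 as follows: ((ethoxycarbonyl)methyl)sulfanyl in place of 4-(ethoxycarbonyl)butyl on a saturated chain carbon, four bonds along the chain from a saturated ring carbon. Among the measured compounds shown here, no measured step touches this part of the molecule: the single step concerns the ester oxygen, and both compound 1 and compound 4 carry the ethyl there. With nothing to guide direction, the step is expected to stay within the scatter, so that a 1.0-fold lower number from compound 1 to compound 4 (0.01 log units; within the scatter) is estimated to be small. Compound 4 is therefore expected to give about 6 mg/kg, with a range from 1.2 mg/kg to 30 mg/kg.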

Compound 4, dose for half-maximal effect: 0.03 mg/kg
The estimate for compound 4 lay 200-fold (2.30 log units) above the measured number; measured number below the stated range.
By their numbers in this assay, from the lowest: compound 2; then compound 4; then compound 3; then compound 1.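

In this assay, the exchange of 4-(ethoxycarbonyl)butyl for ((ethoxycarbonyl)methyl)sulfanyl gives a 210-fold lower number from compound 1 to compound 4 (2.32 log units; beyond the scatter) on a saturated chain carbon, four bonds along the chain from a saturated ring carbon, so the chain itself can move the number a long way, which the earlier single step, confined to the ethyl on the ester oxygen, could not show. Both compounds carry the ethyl ester, yet the step combines two differences: the entering group has 7 heavy atoms against 9 and brings in a sulfur, and this one pair cannot separate the sulfur from the shorter length. Nothing measured here accounts for the size of this step.

On these data alone, what remains open is whether the sulfur or the length matters more, a question that a chain of the same length with an oxygen or a methylene in place of the sulfur would address. As far as these compounds go, it also remains open whether the free carboxylic acid corresponding to compound 4 would give a lower number than its ethyl ester, as the acid compound 2 does against the ester compound 3.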